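The compounds below may be only part of what the source reports. "The series", "measured", "known", "first", "only" and "open" are said of these compounds alone.

In a functional assay on the whole organism with Mus musculus as the target (a lower number here means that less compound is needed, a higher number that more compound is needed for the effect), compound 2 `NC(=O)/C=C1\CCc2c(F)cccc21` has no exact reading. Compound 2 gives > 100 mg/kg, which is a limit of the assay and not a number. Compound 3 `O=C(/C=C1\CCc2c(F)cccc21)NC1CC1`, the cyclopropyl amide, gives 126 mg/kg, and compound 1 `Cc1cccc2c1CC/C2=C\C(=O)NC1CC1` gives 40 mg/kg. The amide step, a step that the limit leaves unreadable from compound 2 to compound 3, therefore offers no size to work with. Compound 4 `Cc1cccc2c1CC/C2=C\C(N)=O` has methyl in place of fluoro on an aromatic carbon. The opposite exchange, fluoro in place of methyl, gave a 3.2-fold higher number from compound 1 to compound 3 (0.50 log units; beyond the scatter), a modest step and the only readable one that bears on this change. A similar modest step toward a lower number is therefore expected, and the estimated change is an at least 2.0-fold lower number from compound 2 to compound 4 (0.30 log units; that floor lies within the scatter). For compound 4 the expected dose is 50 mg/kg, with an estimated range of 20 mg/kg to 125 mg/kg.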

Compound 4, dose for half-maximal effect: > 100 mg/kg
Compound 4 gave a limit, no number; the forecaster's own chance of this, stated with the estimate: 20%; at least 2.0-fold (0.30 log units) between middle value and limit.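

With methyl on the aromatic carbon, hydrogen in place of cyclopropyl on the amide-type nitrogen now has a first readable size in this assay: an at least 2.5-fold higher number from compound 1 to compound 4 (0.39 log units; beyond the scatter). Compound 4 gives > 100 mg/kg, a limit of the assay and not a number. The steps from compound 2 to compound 3 and to compound 4 cannot be read, so the exchange of fluoro and methyl has a size only with cyclopropyl on the nitrogen, because these values stop at a limit: the limit of > 100 mg/kg in this assay, at which 2 of the 4 values shown sit.

Still open, from the compounds shown here alone, is how a longer chain on the amide-type nitrogen would compare with cyclopropyl. Also open, going by these compounds, is how chloro or methoxy on that aromatic carbon would read against methyl and fluoro.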